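The compounds below may be only part of what the source reports. "The series", "measured", "known", "first", "only" and "open" are said of these compounds alone.

Working notes on a small set of styrylsulfonyl anilinoquinazolines tested in a functional assay on HT-29 cells (Homo sapiens); on this read-out higher numbers stand for weaker inhibition of growth and lower numbers for stronger inhibition of growth.

Compound 2 `O=S(=O)(/C=C/c1ccc(C(F)(F)F)cc1F)Cc1ccc(Nc2ncnc3ccccc23)cc1` is the reference point. In this assay compound 2 gives 100000 nM. Compound 1 `O=S(=O)(/C=C/c1ccc(F)cc1F)Cc1ccc(Nc2ncnc3ccccc23)cc1` differs from compound 2 by fluoro in place of trifluoromethyl on an aromatic carbon. For compound 1 this assay returns only a limit, > 100000 nM, and not a number. The step of a number no lower from compound 2 to compound 1 (the limit leaves the size open) therefore cannot be sized; it rests on (the limit of > 100000 nM in this assay, at which 1 of the 3 values shown sits).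

Compound 3 `O=S(=O)(/C=C/c1ccc(C(F)(F)F)cc1F)Cc1ccc(Nc2ncnc3ccc(Br)cc23)cc1` carries a different core, the difference from compound 2 being (bromo in place of hydrogen on an aromatic carbon). In this assay compound 3 gives 100000 nM, and the step of no change at the digits printed from compound 2 to compound 3 (within the scatter) shows no separation from compound 2 at the digits recorded.

Compound 4 `O=S(=O)(/C=C/c1ccc(F)cc1F)Cc1ccc(Nc2ncnc3ccc(Br)cc23)cc1` has not yet been measured. It relates to compound 3 as compound 1 relates to compound 2: the change is fluoro in place of trifluoromethyl on an aromatic carbon. The place described for this change reads word for word as for the change from compound 2 to compound 1, so the two changes are the same, set on the two cores that differ as told above.

On the earlier pair the change did not lower the value, and compound 3 already stands at the same reading as compound 2, so the expected step for compound 4 is no change at the digits printed from compound 3 to compound 4 (within the scatter). The estimate for compound 4 in this assay is 100000 nM, with a range from 50000 nM to 300000 nM, and it is expected that the assay may again report only a limit.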

Compound 4, concentration for 50% growth inhibition: 100000 nM
Compound 4: middle estimate and measured number agree at the digits printed; the range from low to high includes it.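

In this assay, replacing 2-fluoro-4-(trifluoromethyl)phenyl with 2,4-difluorophenyl on the bromo-bearing core gives no change at the digits printed from compound 3 to compound 4 (within the scatter), so this change shows no separation on that core at the digits recorded. Bromo in place of hydrogen gives a number no higher from compound 1 to compound 4 (the limit leaves the size open); this step and the others that rest on the limit cannot be read, so the result neither confirms nor rules out that the change behaves alike on the two cores: the same change on two cores in this assay, a number no lower (the limit leaves the size open) from compound 2 to compound 1 and no change at the digits printed (within the scatter) from compound 3 to compound 4; the limit leaves it open whether they differ. Compound 1 gives > 100000 nM, which is a limit and not a number, so the comparison of the bromo change across the two aryl groups also remains without a size: the same change on two cores in this assay, no change at the digits printed (within the scatter) from compound 2 to compound 3 and a number no higher (the limit leaves the size open) from compound 1 to compound 4; the limit leaves it open whether they differ.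

The compounds shown leave open whether an amine or a carboxylic acid in place of trifluoromethyl or fluoro, on the same aromatic carbon, would give a reading in this assay that separates from that of compound 4, which stands at 100000 nM. Also open, on these data alone, is whether a longer chain in place of the bromo group would separate from compound 3, since bromo and hydrogen are the only two options compared at that place on the core.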